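From Ethyl to Methyl on a Shared Core

This account rests on a few compounds, and the source may have more. Where it says the series, first, only, none or still open, it means among the compounds named here.

Measured so far:
compound 1 `Fc1ccccc1-c1cn2ccnc2c(-c2ccc3ncn(C4CCCCC4)c3c2)n1`: 14.1%
compound 2 `CCc1ccc(-c2cn3ccnc3c(-c3ccc4ncn(Cc5ccccc5)c4c3)n2)cc1`: 30.8%

In a functional assay on OVCAR-8 cells (Homo sapiens) for inhibition, read by sulforhodamine B assay, with a stated time of 48 h, tested at 10 uM (on this read-out lower numbers stand for less inhibition and higher numbers for more inhibition at the one concentration tested (going by the name of the read-out)), compound 1 gives 14.1% and compound 2 gives 30.8%, the higher of the two numbers, with compound 1 standing beyond the scatter below it. Compound 3 `Cc1cccc(-c2cn3ccnc3c(-c3ccc4ncn(Cc5ccccc5)c4c3)n2)c1` has not yet been measured; it differs from compound 2 in one place: 3-methylphenyl in place of 4-ethylphenyl on an aromatic carbon. Among the compounds with values here, no measured pair isolates this change, so its direction cannot be read from what is known. A step of a number 4.8 percentage points lower from compound 2 to compound 3 (within the scatter) is expected, small and within the scatter. Compound 3 is thus estimated at 26%, between 10% and 42%.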

Compound 3, a percentage reported as inhibition, at one concentration (the size of the read-out at that concentration, not a potency): 11.5%
The estimate for compound 3 lay 14.5 percentage points above the measured number, within the range that was stated.
By their numbers in this assay, from the lowest: compounds 3 and 1 (each within the scatter of the next); then compound 2.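

In this assay, putting 3-methylphenyl in place of 4-ethylphenyl on this aromatic carbon gives a number 19.3 percentage points lower from compound 2 to compound 3 (beyond the scatter) and so shows that the read-out responds to the choice of group here, even between two carbon-only aromatic rings without hydrogen-bond donors or acceptors. No measurement at hand explains this step. The change alters both the chain and where it sits, so the compounds shown cannot separate those two effects. Groups such as 4-methylphenyl, 3-ethylphenyl or an amine-bearing phenyl ring remain open.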